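Working notes: chloro in place of fluoro on compound 2

The source may hold more compounds than are shown below. What is called first, only, known or untested is meant among the compounds shown, and "the series" means these compounds.

Measured in a functional assay on MGC-803 cells (Homo sapiens) for inhibition, read by MTT assay, with a stated time of 72 h; a higher number here means a weaker inhibitor, a lower number a stronger inhibitor:
- compound 1 `Cc1ccc(N2CCCC2)c(C(=O)Nc2ccc(CNC(=O)OCc3cccnc3)cc2)c1` gives 19100 nM
- compound 2 `O=C(NCc1ccc(NC(=O)c2cc(F)ccc2N2CCCC2)cc1)OCc1cccnc1` gives 10700 nM
- compound 3 `O=C(NCc1ccc(NC(=O)c2ccc(F)cc2N2CCCC2)cc1)OCc1cccnc1` gives 52100 nM

Compound 2 sits within the scatter of compound 1, while compound 3 stands higher, beyond the scatter from compound 2. Next is compound 4 `O=C(NCc1ccc(NC(=O)c2cc(Cl)ccc2N2CCCC2)cc1)OCc1cccnc1` with chloro in place of fluoro on an aromatic carbon, para to a pyrrolidin-1-yl group and meta to a large group (chloro in place of fluoro on an aromatic carbon) as its single change. For the measured compounds named here, the one measured step at that carbon, fluoro in place of methyl (a 1.8-fold lower number from compound 1 to compound 2 (0.25 log units; within the scatter)), stayed within the scatter, so no step beyond the scatter is expected in this assay here. The expected step is small (a 1.1-fold higher number from compound 2 to compound 4 (0.05 log units; within the scatter)) and rests on that one step alone. For compound 4 the estimated value is 12000 nM with an expected range from 5000 nM to 28000 nM in this assay.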

Compound 4, half-maximal inhibitory concentration: 55500 nM
Estimate against measurement, compound 4: 4.6-fold (0.67 log units) below, and the stated range ends below it.
By their numbers in this assay, from the lowest: compounds 2 and 1 (each within the scatter of the next); then compounds 3 and 4 (each within the scatter of the next).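

Chloro in place of fluoro gives a 5.2-fold higher number from compound 2 to compound 4 (0.71 log units; beyond the scatter) in this assay and shows that this carbon, para to a pyrrolidin-1-yl group, does respond to a single-atom exchange, which the within-scatter step from methyl to fluoro did not show. Chloro also separates from methyl, with a 2.9-fold higher number from compound 1 to compound 4 (0.46 log units; beyond the scatter) at the same carbon, so the fluoro and methyl compounds share a level that chloro does not reach. No measurement here accounts for this.

Going by these compounds, whether bromo, methoxy or an amine at this carbon would track with chloro or with fluoro stays open.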